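This account rests on a few compounds, and the source may have more. Where it says the series, first, only, none or still open, it means among the compounds named here.

Working notes on the series, read in a functional assay on SK-OV-3 cells (Homo sapiens) for cytotoxicity; a lower number here means a stronger inhibitor, a higher number a weaker inhibitor. Compound 1 `C=C/C=C\[C@H](C)[C@H](OC(N)=O)[C@@H](C)[C@H](O)[C@@H](C)C/C(C)=C\[C@H](C)[C@@H](O)[C@@H](C)/C=C\CCc1ccc(Oc2ccccc2)cc1` gives 10000 nM, and compound 2 `C=C/C=C\[C@H](C)[C@H](OC(N)=O)[C@@H](C)[C@H](O)[C@@H](C)C/C(C)=C\[C@H](C)[C@@H](O)[C@@H](C)/C=C\CCc1cccc(O)c1C` gives 270 nM. Compound 2 therefore holds the lower of the two numbers, and its gap to compound 1 lies beyond the scatter. For the measured compounds named here, no measured pair yet differs in a single place, so the data offer no measured step for this kind of change.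

Compound 3 `C=C/C=C\[C@H](C)[C@H](OC(N)=O)[C@@H](C)[C@H](O)[C@@H](C)C/C(C)=C\[C@H](C)[C@@H](O)[C@@H](C)/C=C\CCc1sccc1C` is the next to read: 3-methylthiophen-2-yl in place of 3-hydroxy-2-methylphenyl on a saturated chain carbon, two bonds along the chain from a double-bonded chain carbon. It carries 3-methylthiophen-2-yl in place of 3-hydroxy-2-methylphenyl on a saturated chain carbon, two bonds along the chain from a double-bonded chain carbon.

A moderate rise in the number is expected in this assay, meaning a weaker inhibitor than compound 2, though this expectation rests on very little. The series is known to reach high readings because compound 1 stands at 10000 nM. The expected change is a 4.4-fold higher number from compound 2 to compound 3 (0.65 log units; beyond the scatter), with wide uncertainty. For compound 3 the estimated value is 1200 nM, with an expected range of 300 nM to 5000 nM.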

Compound 3, half-maximal inhibitory concentration: 370 nM
Beside the measured number, compound 3's estimate is 3.2-fold (0.51 log units) above it, and the stated range covers the measured number.
By their numbers in this assay, from the lowest: compounds 2 and 3 (each within the scatter of the next); then compound 1.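

In this assay, for the compounds shown here, the first single-place step reads a 1.4-fold higher number from compound 2 to compound 3 (0.14 log units; within the scatter) for 3-methylthiophen-2-yl in place of 3-hydroxy-2-methylphenyl on a saturated chain carbon, two bonds along the chain from a double-bonded chain carbon. The change goes from a six-membered aromatic ring of carbon only to a five-membered aromatic ring with 1 hetero atom, from 8 heavy atoms to 6, and from 1 hydrogen-bond donor to 0, yet the two compounds stay within the scatter of each other, so in this one pair the reading does not depend on keeping the hydrogen-bond donor. Nothing measured here bears on why the two readings agree.

This is a single pair, so it sets no rule for other aromatic groups at this position, and the tolerance seen here may not extend to other replacements. Still open, going by these compounds, is how the reading responds to an amine or a carboxylic acid on the ring, or to a longer chain between the double-bonded chain carbon and the ring.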